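The compounds below may be only part of what the source reports. "The series", "measured", "known", "first", "only" and "open" are said of these compounds alone.

Measured compounds in this series:

compound 1 `O=C1O/C(=C\Cn2cc(-c3cc(F)cc(F)c3)nn2)C(OCc2ccccc2)=C1OCc1ccccc1` — > 100000 nM
compound 2 `O=C1O[C@H]([C@@H](O)Cn2cc(CNS(=O)(=O)c3ccc(Cl)cc3F)nn2)C(OCc2ccccc2)=C1OCc1ccccc1` — 3390 nM
compound 3 `C[Si](C)(C)c1cn(C[C@H](O)[C@H]2OC(=O)C(OCc3ccccc3)=C2OCc2ccccc2)nn1` — 12100 nM

In a functional assay on MCF7 cells (Homo sapiens) for antiproliferative activity, read by MTT assay, with a stated time of 72 h (on this read-out higher numbers stand for weaker inhibition and lower numbers for stronger inhibition), compound 1 gives > 100000 nM, and this is a limit of the assay, not a number. Its standing on the numbers shown is thus only that it sits at the limit of > 100000 nM in this assay, at which 1 of the 3 values shown sits. Compound 2 gives 3390 nM in this assay. Compound 3 gives 12100 nM in this assay. Both of those carry a saturated core with a hydroxyl on the side chain, whereas compound 1 carries the exocyclic alkene, so no single-change comparison among the measured compounds is available.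

The next compound, compound 4 `O=C1O/C(=C\Cn2cc(-c3cccc(O)c3)nn2)C(OCc2ccccc2)=C1OCc1ccccc1`, keeps the core of compound 1 and differs from it in one place: 3-hydroxyphenyl in place of 3,5-difluorophenyl on an aromatic carbon. Since compound 1 rests at the limit of this assay, the step can only be judged from that limit. The expectation is that the change from compound 1 to compound 4 brings no shift beyond the scatter, so that an at least 1.2-fold lower number from compound 1 to compound 4 (0.09 log units; that floor lies within the scatter) is estimated to remain close to the limit. For compound 4 the expected value in this assay is therefore 80000 nM, with a range from 20000 nM to 300000 nM, and a fair chance that only a limit is again reported.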

Compound 4, half-maximal inhibitory concentration: 27800 nM
The estimate for compound 4 lay 2.9-fold (0.46 log units) above the measured number; low and high end bracket the measured number.
By their numbers in this assay, from the lowest: compound 2; then compound 3; then compound 4. At a limit, above all of these: compound 1.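

In this assay, the aromatic carbon of the five-membered aromatic ring with 3 nitrogen responds to substitution on the core of compound 1: 3-hydroxyphenyl in place of 3,5-difluorophenyl gives an at least 3.5-fold lower number from compound 1 to compound 4 (0.55 log units; beyond the scatter), and compound 4 sits at 27800 nM. As far as these compounds go, the value of compound 1 is a limit and not a number, so this step has only a floor and its full size stays unknown: the limit of > 100000 nM in this assay, at which 1 of the 4 values shown sits. The entering group brings 1 hydrogen-bond donor and 1 hydrogen-bond acceptor where the leaving group has none, and it also lacks the two fluorines, so this single pair cannot say which of these differences goes with the step.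

Still open, from the compounds shown here alone, is whether the hydroxyl itself matters or the loss of fluorine is enough, a question that unsubstituted phenyl, 3-methoxyphenyl or 3-aminophenyl at this carbon on the same core would help to separate. Within the data shown here, also open is how the core of compound 1 compares with the hydroxyl-bearing side chain of compound 2 and compound 3, as no pair linking them differs in one place only.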